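Chloro added to the aryl ether of an aminotriazine

The source may hold more compounds than are shown below. What is called first, only, known or untested is meant among the compounds shown, and "the series" means these compounds.

Compound 1 `CN1CCN(c2nc(N)nc(COc3cccc(Cl)c3)n2)CC1` gives 5820 nM in an assay on HEK293 cells for displacement of a labelled ligand from 5-hydroxytryptamine receptor 7 (Homo sapiens), read by radioligand binding, with a stated time of 1 h; on this read-out higher numbers stand for weaker inhibition and lower numbers for stronger inhibition.
Compound 2 `Cc1ccccc1OCc1nc(N)nc(N2CCN(C)CC2)n1` gives 514 nM in this assay.

Compound 2 stands lowest of the two numbers, with an 11-fold lower number from compound 1 to compound 2 (1.05 log units; beyond the scatter) separating it from compound 1. Compound 3 `Cc1cc(Cl)ccc1OCc1nc(N)nc(N2CCN(C)CC2)n1` carries chloro in place of hydrogen on an aromatic carbon — the substituent sits meta to a methyl group and para to a large group, reading 2-methylphenyl to 4-chloro-2-methylphenyl. For the measured compounds named here, no measured step adds a single chloro to this ring; the one step known swaps the whole aryl group, so it bears only loosely here. Compound 3 is therefore expected to land near compound 2, an estimated 1.3-fold lower number from compound 2 to compound 3 (0.11 log units; within the scatter) in this assay. The estimate for compound 3 is 400 nM, between 120 nM and 1500 nM.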

Compound 3, inhibition constant: 15200 nM
For compound 3 the middle estimate is 38-fold (1.58 log units) below the measured one; the measured number lies above the stated range.
By their numbers in this assay, from the lowest: compound 2; then compound 1; then compound 3.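

In this assay, chloro in place of hydrogen on an aromatic carbon, para to a large group, gives a 30-fold higher number from compound 2 to compound 3 (1.47 log units; beyond the scatter) as a large loss, so this position on the 2-methylphenyl ring responds strongly to a single added atom. The gain that 2-methylphenyl showed over 3-chlorophenyl does not survive this addition, and 4-chloro-2-methylphenyl gives a 2.6-fold higher number from compound 1 to compound 3 (0.42 log units; beyond the scatter) as a modest loss. No evidence here accounts for this loss.

On these data alone, whether fluoro or methoxy at this position would behave as chloro does remains open. So does whether chloro there costs as much on a ring without the methyl group.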